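The source may report more compounds than this note shows. Statements on the series, on what has been measured and on what is new or still open speak of the compounds shown alone.

Working notes on the nitropyrrole thiosemicarbazide series. Compound 3 `COc1cc(NC(=S)NNC(=O)c2cc([N+](=O)[O-])c[nH]2)cc(OC)c1OC` gives 328000 nM in an ADME assay on Vero cells (Chlorocebus sabaeus) for cytotoxicity, read by MTT assay, with a stated time of 72 h; on this read-out lower numbers stand for stronger inhibition and higher numbers for weaker inhibition. Compound 2 `COc1cc(NC(=S)NNC(=O)c2cc([N+](=O)[O-])cn2C)cc(OC)c1OC` differs from it by methyl in place of hydrogen on an aromatic nitrogen and gives 392000 nM in this assay; the step is a 1.2-fold higher number from compound 3 to compound 2 (0.08 log units; within the scatter). Compound 1 `Cc1ccccc1NC(=S)NNC(=O)c1cc([N+](=O)[O-])c[nH]1` carries a different core, and the difference between the two cores is not broken down here. In this assay compound 1 gives 462000 nM, which lies within the scatter of both compound 2 and compound 3. Compound 4 `Cc1ccccc1NC(=S)NNC(=O)c1cc([N+](=O)[O-])cn1C` remains unmeasured; it differs from compound 1 by methyl in place of hydrogen on an aromatic nitrogen, the same change as that from compound 3 to compound 2. Because a 1.2-fold higher number from compound 3 to compound 2 (0.08 log units; within the scatter) stayed within the scatter, the step from compound 1 to compound 4 in this assay is expected to be a 1.1-fold higher number from compound 1 to compound 4 (0.03 log units; within the scatter). Compound 4 is accordingly estimated at 500000 nM, with a likely range from 300000 nM to 850000 nM.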

Compound 4, half-maximal inhibitory concentration: 471000 nM
The estimate for compound 4 lay 1.1-fold (0.03 log units) above the measured number; measured number inside the range.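

In this assay, methyl in place of hydrogen on an aromatic nitrogen gives a 1.0-fold higher number from compound 1 to compound 4 (0.01 log units; within the scatter). Set beside the earlier step, the change reads alike on both cores: the same change on two cores in this assay, a 1.2-fold higher number (0.08 log units; within the scatter) from compound 3 to compound 2 and a 1.0-fold higher number (0.01 log units; within the scatter) from compound 1 to compound 4, 1.2-fold (0.07 log units) apart, within the scatter of two such steps. Among the compounds shown here, this shows only that on these two cores the change leaves the number within the scatter; with no step of real size on either core, the agreement does not show that a larger effect would carry over, nor does it set a rule for other cores.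

The compounds shown leave open how a longer chain such as ethyl would read on that aromatic nitrogen in this assay. The same holds for an amine or a nitrile in place of the nitro group.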